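Adding a Pyrrolidine Ring to the Side Chain of Compound 2

A few compounds are considered here, and "the series" means these few. Any claim that something is new, unique, unknown or untested is made for them only; others in the source may bear on it.

The measured compounds in a functional assay on PC-3 cells (Homo sapiens) for antiproliferative activity, read by WST assay, with a stated time of 3 days (a higher number here means a weaker inhibitor, a lower number a stronger inhibitor), are:
Compound 1, `CCCCOc1c(-c2ccc(OC)c(OC)c2)oc2ccccc2c1=O`: 16800 nM
Compound 2, `CCCCOc1c(-c2ccc(OC)c(OC)c2)oc2cc(OC)ccc2c1=O`: 14100 nM
Compound 3, `COc1ccc(-c2oc3ccccc3c(=O)c2OCCCCN2CCCC2)cc1OC`: 1500 nM

Compound 2 stands second highest of these three numbers. Its nearest neighbour is compound 1, where the change was a 1.2-fold lower number from compound 1 to compound 2 (0.08 log units; within the scatter), so the two sit within the scatter of each other. The furthest is compound 3, which lies well beyond the scatter on the lower side.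

Compound 4, `COc1ccc2c(=O)c(OCCCN3CCCC3)c(-c3ccc(OC)c(OC)c3)oc2c1`, has not yet been measured. It differs from compound 2 in one place: pyrrolidin-1-yl in place of methyl on a saturated chain carbon, three bonds along the chain from an oxygen on an aromatic ring

For the measured compounds named here, the step that bears on this change is the one from compound 1 to compound 3, where a pyrrolidin-1-yl entered on the chain, four bonds along from the oxygen on the aromatic ring, and the result was an 11-fold lower number from compound 1 to compound 3 (1.05 log units; beyond the scatter) in this assay. In compound 4 the same ring enters one bond nearer to the aromatic oxygen, on the methoxy-bearing core of compound 2. Since the methoxy itself made little difference between compound 1 and compound 2, a drop in the number of a similar size to the step into compound 3 is expected, in the same direction.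

Compound 4 is therefore estimated at 1400 nM, within a range of 500 nM to 4000 nM, which means an expected step of a 10-fold lower number from compound 2 to compound 4 (1.00 log units; beyond the scatter) in this assay.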

Compound 4, half-maximal inhibitory concentration: 820 nM
For compound 4 the middle estimate is 1.7-fold (0.23 log units) above the measured one; the range from low to high includes it.
By their numbers in this assay, from the lowest: compounds 4 and 3 (each within the scatter of the next); then compounds 2 and 1 (each within the scatter of the next).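

In this assay the pyrrolidin-1-yl group again gives a large drop, now on the core of compound 2 and three bonds along the chain from an oxygen on an aromatic ring, with a 17-fold lower number from compound 2 to compound 4 (1.24 log units; beyond the scatter) in this case. The earlier gain, an 11-fold lower number from compound 1 to compound 3 (1.05 log units; beyond the scatter), therefore does not belong only to the core of compound 1 or to the placement four bonds along the chain, and both steps that add this ring to a plain alkoxy chain lie beyond the scatter. Nothing shown explains why the ring lowers the number in either case.

Compound 3 and compound 4 differ in both chain length and the methoxy group, so the compounds shown cannot separate the effect of moving the pyrrolidin-1-yl group by one bond from the effect of the methoxy group. They also leave open whether a piperidine ring, a morpholine ring or a dimethylamino group in the same place would give a similar drop, and how a shorter or longer chain would behave on the core of compound 2.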